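From acetyl to 2-fluorophenyl: working notes on compound 4

This account rests on a few compounds, and the source may have more. Where it says the series, first, only, none or still open, it means among the compounds named here.

Measured in an ADME assay on MT4 cells (Homo sapiens) for cytotoxicity; on this read-out lower numbers stand for higher toxicity in this test and higher numbers for lower toxicity in this test:
- compound 1 `O=C(NC(=S)Nc1cccc(C(F)(F)F)c1)c1ccccc1`: > 100000 nM (a limit)
- compound 2 `Fc1ccc(NC(=S)Nc2cccc(C(F)(F)F)c2)cc1`: 31000 nM
- compound 3 `CC(=O)NC(=S)Nc1cccc(C(F)(F)F)c1`: > 100000 nM (a limit)

Compound 3 reads > 100000 nM, which is a limit and not a number. Its place is the limit of > 100000 nM in this assay, at which 2 of the 3 values shown sit.

The change leading to compound 4 `Fc1ccccc1NC(=S)Nc1cccc(C(F)(F)F)c1` is 2-fluorophenyl in place of acetyl on an amide-type nitrogen. In words, 2-fluorophenyl stands in place of acetyl on an amide-type nitrogen.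

Among the compounds with values here, two measured steps bear on this. Within the data shown here, the first is a step that the two limits leave unreadable from compound 1 to compound 3, so it offers no size to work from. The second is an at least 3.2-fold higher number from compound 2 to compound 3 (0.50 log units; beyond the scatter), with acetyl in place of 4-fluorophenyl on an amide-type nitrogen. Among the measured compounds shown here, only this one pair guides the expectation, and read in reverse it points to a lower number in this assay once an aryl group replaces acetyl. The estimated step is an at least 3.3-fold lower number from compound 3 to compound 4 (0.52 log units; beyond the scatter), in the direction of a lower number. The reasoning leans on compound 2 at 31000 nM as the nearest measured value. The expected value for compound 4 is 30000 nM, with an estimated range of 12000 nM to 80000 nM.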

Compound 4, half-maximal cytotoxic concentration: 47000 nM
Compound 4: the middle estimate sits 1.6-fold (0.19 log units) below what was measured; low and high end bracket the measured number.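

In this assay, within the data shown here, the step of an at least 2.1-fold lower number from compound 3 to compound 4 (0.32 log units; beyond the scatter) gives the first reading of 2-fluorophenyl in place of acetyl on this amide-type nitrogen, and it lies beyond the scatter. Compared with the other fluorophenyl compound, the step of a 1.5-fold higher number from compound 2 to compound 4 (0.18 log units; within the scatter) lies within the scatter, so 2-fluorophenyl and 4-fluorophenyl cannot be told apart on this read-out. The value of compound 3 is a limit and not a number, so the first step has a minimum size only: the limit of > 100000 nM in this assay, at which 2 of the 4 values shown sit.

The compounds shown leave open how an amine or a longer carbon chain would read on this nitrogen in this assay. They also leave open whether an unsubstituted phenyl group would read like the two fluorophenyl groups, so no role can yet be given to the fluorine.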